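Thiophene for methyl on the chain carbon of compound 2

The compounds below may be only part of what the source reports. "The series", "measured", "known", "first", "only" and "open" are said of these compounds alone.

Compound 2 `C/C(=C\CCCCC(=O)O)c1cccnc1` was tested in an assay (Equus caballus) for inhibition of Thromboxane-A synthase (Homo sapiens), using microsomes (on this read-out lower numbers stand for stronger inhibition and higher numbers for weaker inhibition), and gives 210 nM. Of the two numbers in hand this is the lowest, but its neighbour compound 1 `O=C(O)CCC/C=C(/c1ccccc1)c1cccnc1` lies close: in this assay compound 1 gives 280 nM, and the gap between the two values is within the scatter, so neither compound can be called the stronger inhibitor.

Compound 3 `O=C(O)CCCC/C=C(/c1cccnc1)c1ccsc1` has not yet been measured. It differs from compound 2 in one place: thiophen-3-yl in place of methyl on a double-bonded chain carbon bound to an aromatic carbon and a double-bonded chain carbon. Going by the values given here, no step between measured compounds covers such a change. What the data do show is that compound 1, which carries an aromatic ring on the corresponding chain carbon, and compound 2, which carries a methyl there, give values within the scatter of each other. On that basis the step from compound 2 to compound 3 is expected to be small, with no direction beyond the scatter, estimated as a 1.2-fold higher number from compound 2 to compound 3 (0.08 log units; within the scatter). Compound 3 is therefore expected to give about 250 nM in this assay, with a likely range from 80 nM to 800 nM.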

Compound 3, half-maximal inhibitory concentration: 62 nM
Compound 3: the middle estimate sits 4.0-fold (0.61 log units) above what was measured, outside the stated range (below it).
By their numbers in this assay, from the lowest: compound 3; then compounds 2 and 1 (each within the scatter of the next).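

In this assay, the double-bonded chain carbon bound to an aromatic carbon and a double-bonded chain carbon proves to be a place where the group matters: thiophen-3-yl in place of methyl gives a 3.4-fold lower number from compound 2 to compound 3 (0.53 log units; beyond the scatter). Going by these compounds alone, the earlier compounds offered no step that changed this group alone, so this is the first direct reading of the position. It shows that the methyl, a single carbon, can give way to a ring of five heavy atoms with a gain in inhibition rather than a loss, although the step is modest and rests on this one pair. No measurement in hand accounts for the size or direction of this step.

The compounds shown leave open whether the gain belongs to thiophen-3-yl in particular or would also appear with another ring on the same carbon, such as thiophen-2-yl or furan-3-yl. They also leave open how far a small group such as ethyl would move the number from that of compound 2, which would show whether a ring is needed at all.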